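The source may report more compounds than this note shows. Statements on the series, on what has been measured and on what is new or still open speak of the compounds shown alone.

Measured so far in a functional assay on SK-OV-3 cells (Homo sapiens) for antiproliferative activity, read by MTT assay, with a stated time of 72 h; a higher number here means a weaker inhibitor, a lower number a stronger inhibitor:

- compound 1, `O=C(CCc1cccc2c1B(O)OC2)Nc1ccc(F)cc1`: 720 nM
- compound 2, `COc1ccccc1NC(=O)CCc1cccc2c1B(O)OC2`: 200 nM
- compound 3, `O=C(CCc1cccc2c1B(O)OC2)Nc1cccc(-c2cccc(F)c2)c1`: 480 nM

Compound 3 stands second highest of the three numbers. Its nearest neighbour is compound 1, whose number is higher but within the usual scatter, so the two are not distinguished here. For the measured compounds named here, compound 2 lies furthest from compound 3, with a lower number beyond the scatter, so of the three, compound 2 is the one clearly separated from compound 3.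

The next compound in the series is compound 4, `O=C(CCc1cccc2c1B(O)OC2)Nc1cccc(-c2cccc(C(F)(F)F)c2)c1`. It differs from compound 3 in one place: trifluoromethyl in place of fluoro on an aromatic carbon. Going by the values given here, no pair of measured compounds shares this change, and none of the three measured compounds varies anything on that outer ring, so there is no measured step to lean on. The change touches only the far end of the molecule, away from the shared core and the amide. The expectation for this assay is a step of no more than the scatter, in either direction, with a slight lean toward a lower number. Compound 4 is therefore estimated at 400 nM, with a range of 150 nM to 1100 nM, meaning an expected step of a 1.2-fold lower number from compound 3 to compound 4 (0.08 log units; within the scatter).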

Compound 4, half-maximal inhibitory concentration: 390 nM
Estimate against measurement, compound 4: 1.0-fold (0.01 log units) above; the measured number falls inside the stated range.
By their numbers in this assay, from the lowest: compounds 2, 4, 3 and 1 (each within the scatter of the next, the first and the last beyond it).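

In this assay, trifluoromethyl in place of fluoro on the outer ring gives a 1.2-fold lower number from compound 3 to compound 4 (0.09 log units; within the scatter), so the two compounds are not distinguished. For the compounds shown here, this is the first measured step on that ring, where none of the earlier compounds varied anything, and it shows that this aromatic carbon, meta to a large group, carries either 3-fluorophenyl or 3-(trifluoromethyl)phenyl without a readable difference in antiproliferative potency, despite the rise from 1 heavy atom to 4. No measured property of these compounds bears on why the two read alike.

On these data alone, both groups at this position count 0 hydrogen-bond donors and 0 hydrogen-bond acceptors, so it remains open whether an amine or a carboxylic acid on the same carbon would also stay within the scatter of compound 3. Also open, as far as these compounds go, is whether trifluoromethyl in place of fluoro on the simpler aromatic ring of compound 1 would give a step of similar size, as this single pair cannot show whether the result extends beyond the outer ring.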